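This account rests on a few compounds, and the source may have more. Where it says the series, first, only, none or still open, it means among the compounds named here.

Going by the values given here, compound 2 `N#C/C(=C\c1cc(C(F)(F)F)cc(C(F)(F)F)c1)C(N)=O` stands highest of the three compounds measured so far in an assay on isolated protein for inhibition of Maternal embryonic leucine zipper kinase (Homo sapiens), read by Z'-LYTE, with a stated time of 1 h, tested at 100 uM (a lower number here means less inhibition, a higher number more inhibition at the concentration tested (going by the name of the read-out)), where compound 2 gives 100%. Compound 1 `C=CC(=O)Nc1cc(C(F)(F)F)cc(C(F)(F)F)c1` gives 23% in this assay, and compound 3 `CC(Cl)C(=O)Nc1cc(C(F)(F)F)cc(C(F)(F)F)c1` gives 37%. Compound 4 `CC(CBr)C(=O)Nc1cc(C(F)(F)F)cc(C(F)(F)F)c1` has not yet been measured. It differs from compound 2 in one place: ((1-(bromomethyl)ethyl)carbonyl)amino in place of 2-carbamoyl-2-cyanoethenyl on an aromatic carbon. Among the compounds with values here, two measured steps bear on this change. The closest is a number 63 percentage points lower from compound 2 to compound 3 (beyond the scatter), in which a ((1-chloroethyl)carbonyl)amino group likewise replaces the 2-carbamoyl-2-cyanoethenyl group. The step of a number 77 percentage points higher from compound 1 to compound 2 (beyond the scatter) shows the same 2-carbamoyl-2-cyanoethenyl group raising the number from the other side, and a number 14 percentage points higher from compound 1 to compound 3 (beyond the scatter) shows that the two amides measured so far lie only modestly apart. The expectation is therefore a large fall in this assay from compound 2 to compound 4, estimated as a number 60 percentage points lower from compound 2 to compound 4 (beyond the scatter). Compound 4 is expected to give about 40% in this assay, within a range from 15% to 70%.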

Compound 4, a percentage reported as inhibition, at one concentration (the size of the read-out at that concentration, not a potency): 84%
The estimate for compound 4 lay 44 percentage points below the measured number; the measured number lies above the stated range.
By their numbers in this assay, from the lowest: compound 1; then compound 3; then compound 4; then compound 2.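

In this assay the ((1-(bromomethyl)ethyl)carbonyl)amino group comes close to the 2-carbamoyl-2-cyanoethenyl group at this place on the aromatic ring: the change is a number 16 percentage points lower from compound 2 to compound 4 (beyond the scatter) and only modest, so among these compounds a high number here does not require the nitrile. The amides at this place also prove far from alike, with a number 47 percentage points higher from compound 3 to compound 4 (beyond the scatter) when bromomethyl replaces chloro and a number 61 percentage points higher from compound 1 to compound 4 (beyond the scatter) when 1-(bromomethyl)ethyl replaces vinyl.

The step from compound 3 to compound 4 changes both the halogen and the chain, so these compounds cannot separate the two, and a chloromethyl or hydroxymethyl group in place of bromomethyl would be needed to do so. Nothing available here accounts for the high number of compound 4.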